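This account rests on a few compounds, and the source may have more. Where it says the series, first, only, none or still open, it means among the compounds named here.

Measured so far:
- compound 1, `CN(c1ccn(C)n1)c1cnc(NCc2c(F)ccc3c2CCO3)c2cn[nH]c(=O)c12`: 12000 nM
- compound 2, `Cc1nccn1-c1cnc(NCc2c(F)ccc3c2CCO3)c2cn[nH]c(=O)c12`: 7000 nM
- compound 3, `CNC(=O)c1ncc(-c2cnc(NCc3c(F)ccc4c3CCO4)c3cn[nH]c(=O)c23)n1C`: 5000 nM

All three were read in a physicochemical assay for solubility, read by LC-MS, in phosphate buffer, with a stated time of 24 h, at pH 7.4; on this read-out higher numbers stand for higher solubility and lower numbers for lower solubility. Compound 3 gives the lowest of the three numbers: its gap to compound 2, a 1.4-fold lower number from compound 2 to compound 3 (0.15 log units; within the scatter), is within the scatter, while the gap from compound 1, a 2.4-fold lower number from compound 1 to compound 3 (0.38 log units; beyond the scatter), is beyond it, so only against compound 1 can compound 3 be called less soluble.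

Compound 4, `CC(=O)N1CCC(c2cnc(NCc3c(F)ccc4c3CCO4)c3cn[nH]c(=O)c23)CC1`, is not yet measured. Its difference from compound 3 is 1-acetylpiperidin-4-yl in place of 1-methyl-2-(methylcarbamoyl)-1H-imidazol-5-yl on an aromatic carbon. For the measured compounds named here, every measured step so far has exchanged the group at this same carbon: a 1.7-fold lower number from compound 1 to compound 2 (0.23 log units; within the scatter), a 2.4-fold lower number from compound 1 to compound 3 (0.38 log units; beyond the scatter) and a 1.4-fold lower number from compound 2 to compound 3 (0.15 log units; within the scatter), all small or at most modest. None of them exchanges a five-membered aromatic ring for a six-membered non-aromatic ring, so there is no direct guide. Given the small spread seen, the step of a 1.4-fold higher number from compound 3 to compound 4 (0.15 log units; within the scatter) is expected to stay within the scatter, if anything leaning toward a higher number. Compound 4 is therefore estimated at 7000 nM, in the range 2500 nM to 20000 nM.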

Compound 4, solubility: < 2000 nM
Compound 4: a limit, no number; the forecaster's own chance of this, stated with the estimate: 5%; middle value at least 3.5-fold (0.54 log units) from the limit.
By their numbers in this assay, from the lowest: compounds 3, 2 and 1 (each within the scatter of the next, the first and the last beyond it). At a limit, below all of these: compound 4.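

In this assay compound 4 gives < 2000 nM, which is a limit of the assay and not a number. Even so, the steps can be read as minimum sizes, and all are beyond the scatter: an at least 2.5-fold lower number from compound 3 to compound 4 (0.39 log units; beyond the scatter), an at least 3.5-fold lower number from compound 2 to compound 4 (0.54 log units; beyond the scatter) and an at least 6.0-fold lower number from compound 1 to compound 4 (0.77 log units; beyond the scatter). The earlier groups on this aromatic carbon gave numbers only modestly apart at most, so 1-acetylpiperidin-4-yl, the one group shown with a six-membered non-aromatic ring, is the first to show that this position can take the number well past that narrow range.

On these data alone, how far compound 4 truly lies from the others stays unknown: the limit of < 2000 nM in this assay, at which 1 of the 4 values shown sits. Also open is whether the ring or its acetyl group goes with the low reading, and a piperidine with a free amine in place of the acetyl group would separate the two.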